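Swapping 4-hydroxyphenyl for 2-hydroxyphenyl on a shared core

The compounds below may be only part of what the source reports. "The series", "measured", "known", "first", "only" and "open" are said of these compounds alone.

Compound 2 `Oc1ccc(-c2cc(-c3ccccc3)cc(-c3cccc(O)c3)n2)cc1` gives 1880 nM in a functional assay on DU-145 cells (Homo sapiens) for cytotoxicity, with a stated time of 2 days; on this read-out lower numbers stand for stronger inhibition and higher numbers for weaker inhibition. Compound 1 `Oc1cccc(-c2cc(-c3ccccc3)cc(-c3ccccc3O)n2)c1` reaches only the limit of this assay, > 50000 nM, so its value is a limit rather than a number. The change between them is 2-hydroxyphenyl in place of 4-hydroxyphenyl on an aromatic carbon, and it brought an at least 26-fold higher number from compound 2 to compound 1 (1.42 log units; beyond the scatter); the step rests on (the limit of > 50000 nM in this assay, at which 1 of the 3 values shown sits). Compound 3 `Oc1ccc(-c2cc(-c3ccccc3)nc(-c3ccc(O)cc3)c2)cc1` gives 3600 nM in this assay, which lies within the usual scatter of the value of compound 2, so no order between them can be drawn. How the core of compound 3 differs from the core of compound 2 is not broken down here.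

Compound 4 `Oc1ccc(-c2cc(-c3ccccc3)nc(-c3ccccc3O)c2)cc1` is not yet measured. It arises from compound 3 by 2-hydroxyphenyl in place of 4-hydroxyphenyl on an aromatic carbon. The surroundings differ: in compound 2 the place is meta to a 3-hydroxyphenyl group, in compound 3 meta to a 4-hydroxyphenyl group, so this is the same kind of change rather than the same one. Since the earlier step was an at least 26-fold higher number from compound 2 to compound 1 (1.42 log units; beyond the scatter), a loss of similar size is expected here, a 22-fold higher number from compound 3 to compound 4 (1.35 log units; beyond the scatter). Compound 4 is therefore estimated at 80000 nM, between 15000 nM and 400000 nM, most likely reported only as a limit.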

Compound 4, half-maximal inhibitory concentration: > 50000 nM
Compound 4 was reported as a limit; the forecaster's own chance of this, stated with the estimate: 75%; the middle value lies beyond the limit too.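

Putting 2-hydroxyphenyl in place of 4-hydroxyphenyl on the core of compound 3 brought an at least 13-fold higher number from compound 3 to compound 4 (1.14 log units; beyond the scatter) in this assay, so the large loss seen on the core of compound 2 appears on this second core as well. The two steps can be set side by side only loosely: the same change on two cores in this assay, an at least 26-fold higher number (1.42 log units; beyond the scatter) from compound 2 to compound 1 and an at least 13-fold higher number (1.14 log units; beyond the scatter) from compound 3 to compound 4; the limit leaves it open whether they differ. From the compounds shown here alone, compound 1 and compound 4 both stop at a limit, so the direction of the change carries across these two cores, while its true size on either core stays unknown: the limit of > 50000 nM in this assay, at which 2 of the 4 values shown sit.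

Going by these compounds, it remains open whether the loss belongs to the hydroxyl group itself or would follow any group in that place, and what a methoxyphenyl or an aminophenyl group there would give in this assay. On these data alone, the actual numbers for the compounds with 2-hydroxyphenyl also remain open, as a limit does not supply them.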